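The compounds below may be only part of what the source reports. "The series", "measured", "known", "first", "only" and "open" are said of these compounds alone.

Three macrocyclic depsipeptides have been tested in a functional assay on HCT-116 cells (Homo sapiens) for antiproliferative activity, read by MTT assay, with a stated time of 72 h; on this read-out higher numbers stand for weaker inhibition and lower numbers for stronger inhibition. Compound 1 `CC/C1=C\C=C\[C@@H](C)[C@@H](c2ccccc2)OC(=O)[C@H](C(C)C)NC(=O)[C@@H](Cc2cc(Cl)c(O)c(Cl)c2)NC(=O)[C@H](C(C)C)N(C)C(=O)/C(C)=C/C[C@H]1OC` gives 60.3 nM. Compound 2 `CC[C@H](C)[C@H]1C(=O)N[C@H](Cc2cc(Cl)c(O)c(Cl)c2)C(=O)N[C@@H](C(C)(C)O)C(=O)O[C@H](c2ccccc2)C/C=C/C=C(\C)[C@H](OC)C[C@@H]2O[C@@]2(C)C(=O)N1C` gives 78.2 nM. Compound 3 `COc1cc(C[C@H]2NC(=O)[C@H](C(C)C)N(C)C(=O)/C(C)=C/C[C@@H](OC)/C(C)=C/C=C/[C@@H](C)[C@@H](c3ccccc3)OC(=O)[C@H](C(C)C)NC2=O)ccc1O` gives 48.5 nM. On these numbers compound 2 stands together with compound 1 and compound 3, all within the usual scatter of one another, so none of the three separates from the others.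

The step to compound 4 `CC[C@H](C)[C@H]1C(=O)N[C@H](Cc2cc(Cl)c(O)c(Cl)c2)C(=O)N[C@@H](C(C)(C)O)C(=O)O[C@H](c2ccccc2)[C@H](C)/C=C/C=C(\C)[C@H](OC)C[C@@H]2O[C@@]2(C)C(=O)N1C` makes one change to compound 2: methyl in place of hydrogen on a saturated ring carbon. For the measured compounds named here, no pair of measured compounds differs by exactly this change, so nothing measured speaks to its size. Compound 1 and compound 3 carry a methyl at that same ring position and sit close to compound 2, which suggests a step of no more than the scatter. The step expected from compound 2 to compound 4 is therefore a 1.2-fold lower number from compound 2 to compound 4 (0.08 log units; within the scatter). Compound 4 is estimated at 65 nM, within a range of 30 nM to 140 nM.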

Compound 4, half-maximal inhibitory concentration: 17 nM
Compound 4: the middle estimate sits 3.8-fold (0.58 log units) above what was measured; measured number below the stated range.
By their numbers in this assay, from the lowest: compound 4; then compounds 3, 1 and 2 (each within the scatter of the next).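

Placing a methyl on this saturated ring carbon, next to the ring atom that bears a phenyl group, gives a 4.6-fold lower number from compound 2 to compound 4 (0.66 log units; beyond the scatter) in this assay. For the compounds shown here, this single added carbon is enough to move the number beyond the scatter, so the position is sensitive to even a small change, which the earlier compounds could not show. Nothing available explains the step. The compounds shown leave open what an ethyl group, a longer chain or a hydroxyl group on this carbon would do. They also leave open whether the methyl would have the same effect on the core of compound 1 or compound 3.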